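Swapping the Aryl Group on the Triazole Nitrogen

A few compounds are considered here, and "the series" means these few. Any claim that something is new, unique, unknown or untested is made for them only; others in the source may bear on it.

Of the compounds shown here, two in this set have been tested in a functional assay on PC-3 cells (Homo sapiens) for inhibition, read by MTT assay, with a stated time of 72 h; a higher number here means a weaker inhibitor, a lower number a stronger inhibitor. Compound 1 `CC(C)(C)OC(=O)N1CCN(C(=S)SCc2cn(-c3ccccc3F)nn2)CC1` carries a tert-butyl carbamate on its piperazine and a 2-fluorophenyl group. In this assay compound 1 gives only a limit, > 128000 nM, not a measured number. It therefore stands at the limit of > 128000 nM in this assay, at which 1 of the 2 values shown sits. Compound 2 `Cc1ccc(Cn2cc(CSC(=S)N3CCNCC3)nn2)cc1` differs from compound 1 in more than one place, with a free piperazine and a 4-methylbenzyl group, and in this assay compound 2 gives 19800 nM. These two compounds differ in several places at once. Their values show only that one is a limit and the other a number, and no single change can be tied to that.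

Compound 3 `COc1ccc(-n2cc(CSC(=S)N3CCN(C(=O)OC(C)(C)C)CC3)nn2)cc1` is compound 1 with one change: 4-methoxyphenyl in place of 2-fluorophenyl on an aromatic nitrogen. Within the data shown here, no measured pair covers this change, so the step expected in this assay is an at least 1.1-fold lower number from compound 1 to compound 3 (0.06 log units; that floor lies within the scatter), a modest one at most and not clearly in either direction. Compound 3 is thus expected to give about 110000 nM in this assay, within 30000 nM to 300000 nM, with a fair chance that only a limit is reported again.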

Compound 3, half-maximal inhibitory concentration: > 128000 nM
Compound 3 ended at the assay's limit; the forecaster's own chance of this, stated with the estimate: 60%; middle value at least 1.1-fold (0.06 log units) away from the limit.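

In this assay compound 3 gives > 128000 nM as a limit, not a measured number. Compound 1 gives a limit too, so no step can be read between compound 1 and compound 3: the limit of > 128000 nM in this assay, at which 2 of the 3 values shown sit. The compounds shown leave open whether 4-methoxyphenyl in place of 2-fluorophenyl changes inhibition at all.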